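This account rests on a few compounds, and the source may have more. Where it says the series, first, only, none or still open, it means among the compounds named here.

Compound 1 `CCOc1ccc(-c2cccc(C(=O)N3CCCC3)c2)cc1` and compound 2 `CCOc1ccc(-c2cccc(NC(C)=O)c2)cc1` share a common core and differ only in the group carried on one aromatic carbon. In an assay on COS-7 cells for inhibition of patatin-like phospholipase domain-containing protein 2 (Mus musculus), tested at 200 uM (a higher number here means more inhibition at the concentration tested (going by the name of the read-out), a lower number less inhibition), compound 1 gives 53%, and in the same assay compound 2 gives 52%. Going by the values given here, the single measured step, a number 1 percentage points lower from compound 1 to compound 2 (within the scatter), exchanges acetamido for (pyrrolidin-1-yl)carbonyl on an aromatic carbon, and its size lies within the usual scatter. Compound 2 therefore stands on a number that sits alongside that of compound 1, the two indistinguishable on these data.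

Compound 3 `CCOc1ccc(-c2cccc(NC(=O)N(C)C)c2)cc1` is built from compound 2 by the change (dimethylamino in place of methyl on a carbonyl carbon). Among the compounds with values here, no measured step touches a carbonyl carbon in this way; the one step available alters the whole group on the aromatic carbon rather than a substituent on the carbonyl, so it offers no direct guidance for the size or direction of what follows. With nothing pointing one way or the other, the step is expected to be a number 2 percentage points lower from compound 2 to compound 3 (within the scatter), that is, nothing beyond the scatter. Compound 3 is accordingly estimated at 50%, with a range from 30% to 70%.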

Compound 3, a percentage reported as inhibition, at one concentration (the size of the read-out at that concentration, not a potency): 68%
Estimate against measurement, compound 3: 18 percentage points below, within the range that was stated.
By their numbers in this assay, from the lowest: compounds 2 and 1 (each within the scatter of the next); then compound 3.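

In this assay, the carbonyl carbon of the acetamido group proves to be a place where a change registers: dimethylamino in place of methyl gives a number 16 percentage points higher from compound 2 to compound 3 (beyond the scatter), whereas the earlier exchange on the aromatic carbon stayed within the scatter. Set against the (pyrrolidin-1-yl)carbonyl group on that same aromatic carbon, the (dimethylcarbamoyl)amino group also gives a number 15 percentage points higher from compound 1 to compound 3 (beyond the scatter), so compound 3 stands clear of both earlier compounds, which remain indistinguishable from each other. No measurement is at hand that explains this rise, and it rests on a single concentration.

Going by these compounds, it remains open whether the rise goes with the nitrogen on the carbonyl carbon, with its two methyl groups or with the size of the whole group; a methylamino or a plain amino group on that carbon would begin to separate these readings. Equally open, on these data alone, is how a ring amine such as pyrrolidin-1-yl or morpholin-4-yl would compare with dimethylamino there, and whether the higher number at this one concentration would carry over to a measured potency.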